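A few compounds are considered here, and "the series" means these few. Any claim that something is new, unique, unknown or untested is made for them only; others in the source may bear on it.

In a functional assay on aorta (Rattus norvegicus, strain Sprague-Dawley) (on this read-out lower numbers stand for an effect already at smaller amounts and higher numbers for an effect only at larger amounts of compound), three compounds of one series have been looked at so far. Compound 1 `Cc1nn(-c2ccccc2)c2nc(O)c(-c3nc(N)cc(N)n3)cc12` is reported as "not determined" (no result reported), so it offers no number to compare. Compound 2 `Cc1ccccc1COc1nc2c(cc1-c1nc(N)cc(N)n1)c(C)nn2-c1ccccc1` gives 290 nM, and compound 3 `Cc1nn(-c2ccccc2)c2nc(OCc3ccccc3F)c(-c3nc(N)c(N4CCCCC4)c(N)n3)cc12` gives 790 nM, the higher of the two numbers, with a gap beyond the usual scatter. Compound 4 `Cc1nn(-c2ccccc2)c2nc(OCc3ccccc3F)c(-c3nc(N)c(N(C)C)c(N)n3)cc12` has not been measured yet. It matches compound 3 except for one swap: dimethylamino in place of piperidin-1-yl on an aromatic carbon. For the measured compounds named here, no measured pair shows what such a swap does, so only a small change is expected. The estimated result is a step of a 1.6-fold lower number from compound 3 to compound 4 (0.20 log units; within the scatter) that stays within the scatter. For compound 4 the expected value is 500 nM, with a likely range from 150 nM to 1600 nM.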

Compound 4, half-maximal effective concentration: 1100 nM
The estimate for compound 4 lay 2.2-fold (0.34 log units) below the measured number; the measured number falls inside the stated range.
By their numbers in this assay, from the lowest: compound 2; then compounds 3 and 4 (each within the scatter of the next).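

In this assay, the one swap shown at this position, dimethylamino in place of piperidin-1-yl, comes with a 1.4-fold higher number from compound 3 to compound 4 (0.14 log units; within the scatter). So on this aromatic carbon, ortho to two amino groups, an open dimethylamino and a six-membered non-aromatic ring cannot be told apart on this read-out. No measurement at hand bears on this result. Still open, from the compounds shown here alone, is whether a morpholin-4-yl ring or a carboxylic acid on the same carbon would also stay within the scatter of these two compounds.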